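From Cyclopropylsulfonyl to Dimethylpiperazinylcarbonyl: An Expected Shift

This account rests on a few compounds, and the source may have more. Where it says the series, first, only, none or still open, it means among the compounds named here.

Compound 1 `COc1cc(O)c2c(=O)cc(-c3ccc(NS(=O)(=O)C4CC4)cc3)oc2c1OC(C)C` carries a cyclopropylsulfonyl group on a nitrogen on an aromatic ring. In a functional assay on DU-145 cells (Homo sapiens) for antiproliferative activity, read by MTT assay, with a stated time of 3 days (on this read-out higher numbers stand for weaker inhibition and lower numbers for stronger inhibition), compound 1 gives 48700 nM, the highest of the two numbers measured. Compound 2 `COc1cc(O)c2c(=O)cc(-c3ccc(NC(=O)N4CCNCC4)cc3)oc2c1OC(C)C` gives 8000 nM, and the change a 6.1-fold lower number from compound 1 to compound 2 (0.78 log units; beyond the scatter). Compound 3 `COc1cc(O)c2c(=O)cc(-c3ccc(NC(=O)N4CC(C)NC(C)C4)cc3)oc2c1OC(C)C` is related to compound 1 by (3,5-dimethylpiperazin-1-yl)carbonyl in place of cyclopropylsulfonyl on a nitrogen on an aromatic ring, the same kind of exchange that produced compound 2. Because a 6.1-fold lower number from compound 1 to compound 2 (0.78 log units; beyond the scatter) was modest, a fall of similar size is expected, a 4.9-fold lower number from compound 1 to compound 3 (0.69 log units; beyond the scatter). Compound 3 is therefore estimated at 10000 nM, with a likely range from 3000 nM to 35000 nM.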

Compound 3, half-maximal inhibitory concentration: 41900 nM
Compound 3: middle estimate off by 4.2-fold (0.62 log units), on the low side, outside the stated range (above it).
By their numbers in this assay, from the lowest: compound 2; then compounds 3 and 1 (each within the scatter of the next).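

In this assay there is a 1.2-fold lower number from compound 1 to compound 3 (0.07 log units; within the scatter) on exchanging cyclopropylsulfonyl for (3,5-dimethylpiperazin-1-yl)carbonyl on this nitrogen, so a piperazine ring joined through a carbonyl does not by itself bring the lower number seen for compound 2. Adding the two methyl groups to that ring gives a 5.2-fold higher number from compound 2 to compound 3 (0.72 log units; beyond the scatter) and removes the earlier gain, so this position responds to a small change on the ring. No evidence is available to explain this difference. Still open, going by these compounds, is whether one methyl group on the piperazine ring would behave like none or like two, and how a morpholine ring would compare.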